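This account rests on a few compounds, and the source may have more. Where it says the series, first, only, none or still open, it means among the compounds named here.

Compound 1 `Oc1ccc(CNc2cc(C(F)(F)F)cc3[nH]ncc23)cc1`: 75%
Compound 2 `FC(F)(F)c1cc(NC[C@H]2CCCN2)c2cn[nH]c2c1`: 55%
Compound 3 `N#Cc1cc(NCc2ccccc2[N+](=O)[O-])c2cn[nH]c2c1`: 22%

In an assay for inhibition of Tryptophan 2,3-dioxygenase (Homo sapiens), with stated times of 10 min and 60 min, tested at 10 uM (on this read-out higher numbers stand for a stronger effect at the one concentration tested and lower numbers for a weaker effect), compound 2 gives 55%, the second highest of the three numbers: compound 1 sits higher, beyond the scatter, and compound 3 sits well below it. Compound 4 `FC(F)(F)c1cc(NC[C@@H]2CCCCN2)c2cn[nH]c2c1` has not yet been measured. It differs from compound 2 by piperidin-2-yl in place of pyrrolidin-2-yl on a saturated chain carbon bound to a nitrogen on an aromatic ring. Among the measured compounds shown here, only one measured step exists, a number 20 percentage points lower from compound 1 to compound 2 (beyond the scatter), and it exchanges one whole ring group for a quite different one, not a five-membered non-aromatic ring for a six-membered one; no measured pair shows such a ring enlargement. With nothing directly comparable, a step no larger than the usual scatter is expected, a number 5 percentage points lower from compound 2 to compound 4 (within the scatter), in no firm direction. Compound 4 is therefore expected to give about 50%, somewhere between 25% and 75%.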

Compound 4, a percentage reported as inhibition, at one concentration (the size of the read-out at that concentration, not a potency): 64%
Beside the measured number, compound 4's estimate is 14 percentage points below it; the measured number falls inside the stated range.
By their numbers in this assay, from the lowest: compound 3; then compounds 2 and 4 (each within the scatter of the next); then compound 1.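

In this assay, the pyrrolidin-2-yl and piperidin-2-yl rings on this saturated chain carbon cannot be told apart, with a number 9 percentage points higher from compound 2 to compound 4 (within the scatter), so this position accepts either ring size. The six-membered ring does not match the 4-hydroxyphenyl group, however, with a number 11 percentage points lower from compound 1 to compound 4 (beyond the scatter). No measurement is available that explains these numbers. As far as these compounds go, it remains open whether a seven-membered ring containing nitrogen or an open-chain amine would keep a similar effect at this place. A piperidin-2-yl compound carrying the nitrile of compound 3 would also be informative.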